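A few compounds are considered here, and "the series" means these few. Any claim that something is new, unique, unknown or untested is made for them only; others in the source may bear on it.

Measured in a functional assay on A549 cells (Homo sapiens) for cytotoxicity, read by MTT assay; a lower number here means a stronger inhibitor, a higher number a weaker inhibitor:
Compound 1 `C=C1C(=O)[C@]23C[C@@]1(F)CC[C@H]2[C@@]12C=CC(=O)[C@](C)(C(=O)O1)[C@H]2[C@@H]3C(=O)OC`: 38900 nM
Compound 2 `C=C1C(=O)[C@]23C[C@@]1(F)CC[C@H]2[C@@]12C=CC(=O)[C@](C)(C(=O)O1)[C@H]2[C@@H]3C(=O)OCc1ccccc1`: 64400 nM
Compound 3 `C=C1C(=O)[C@]23C[C@@]1(I)CC[C@H]2[C@@]12C=CC(=O)[C@](C)(C(=O)O1)[C@H]2[C@@H]3C(=O)OC`: 53200 nM

Compound 2, at 64400 nM, stands within the scatter of both other compounds, so the three form a single group on these numbers. The next compound, compound 4 `C=C1C(=O)[C@]23C[C@@]1(OCC)CC[C@H]2[C@@]12C=CC(=O)[C@](C)(C(=O)O1)[C@H]2[C@@H]3C(=O)OCc1ccccc1`, keeps everything in compound 2 except one group: ethoxy in place of fluoro on a saturated ring carbon.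

The closest evidence is the exchange at this same carbon, iodo in place of fluoro, which gave a 1.4-fold higher number from compound 1 to compound 3 (0.14 log units; within the scatter). The other measured change, phenyl in place of hydrogen on a saturated chain carbon bound to an oxygen next to a carbonyl group, gave a 1.7-fold higher number from compound 1 to compound 2 (0.22 log units; within the scatter). It lies elsewhere in the molecule, and compound 4 retains it. Among the compounds with values here, no measured compound carries ethoxy at this carbon, so the expectation rests on a single halogen exchange and is uncertain. Since neither measured step left the scatter, no step beyond the scatter is expected in this assay. The expected change is a 1.2-fold lower number from compound 2 to compound 4 (0.07 log units; within the scatter). For compound 4 the estimated value is 55000 nM, with an expected range of 25000 nM to 120000 nM.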

Compound 4, half-maximal inhibitory concentration: 24200 nM
Estimate against measurement, compound 4: 2.3-fold (0.36 log units) above, outside the stated range (below it).
By their numbers in this assay, from the lowest: compounds 4, 1, 3 and 2 (each within the scatter of the next, the first and the last beyond it).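

In this assay, ethoxy in place of fluoro on this saturated ring carbon gave a 2.7-fold lower number from compound 2 to compound 4 (0.43 log units; beyond the scatter), the only single change shown here that lies beyond the scatter. The earlier exchange at the same carbon, iodo in place of fluoro, gave a 1.4-fold higher number from compound 1 to compound 3 (0.14 log units; within the scatter) and so offered no sign that this position could shift the number; compound 4 shows that it can, at least for ethoxy alongside the benzyl ester of compound 2. The step replaces a single fluorine with a three-atom group holding one hydrogen-bond acceptor, but the data shown offer no measurement that explains why the number fell.

The compounds shown leave open whether the step follows from the oxygen bound to this carbon or from the ethyl chain on it, a question that a hydroxyl group, methoxy, a longer alkoxy chain or an amine at the same carbon would help to separate. They also leave open whether ethoxy would give a step of similar size alongside the methyl ester of compound 1.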